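A few compounds are considered here, and "the series" means these few. Any claim that something is new, unique, unknown or untested is made for them only; others in the source may bear on it.

Three compounds of this series were tested in an assay on HEK293 cells for negative allosteric modulation of metabotropic glutamate receptor 5 (Homo sapiens), read by FLIPR, with a stated time of 1 h (on this read-out higher numbers stand for weaker inhibition and lower numbers for stronger inhibition), and none gave a number. Compound 1 `Cc1cccc(C#Cc2nc3c(s2)C(=O)NCC3)c1` reached only the limit of > 10000 nM. Compound 3 `O=C(C1CC(F)(F)C1)N1CCc2nc(C#Cc3cccc(F)c3)sc2C1` likewise stopped at > 10000 nM. Compound 2 `O=C(C1CC12CCC2)N1CCc2nc(C#Cc3ccccc3)sc2C1` stands at the same limit, > 10000 nM, so its inhibition is known only as weaker than the assay can resolve, a position shared by every value shown, because of the limit of > 10000 nM in this assay, at which 3 of the 3 values shown sit. Compound 4 `Cc1cccc(C(=O)N2CCc3nc(C#Cc4ccccc4)sc3C2)n1` differs from compound 2 by a group of 7 heavy atoms (6 carbon, 1 nitrogen; one six-membered aromatic ring with 1 hetero atom) in place of a group of 6 heavy atoms (6 carbon; one three-membered non-aromatic ring of carbon only, one four-membered non-aromatic ring of carbon only), on a carbonyl carbon. Going by the values given here, no measured pair tells the size of such a change here. The change from compound 2 to compound 4 is expected to be an at least 6.6-fold lower number from compound 2 to compound 4 (0.82 log units; beyond the scatter), toward stronger inhibition. Compound 4 is estimated at 1500 nM in this assay, within 150 nM to 10000 nM, though a limit again is quite possible.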

Compound 4, half-maximal inhibitory concentration: > 10000 nM
Compound 4: a limit, no number (the forecaster's own chance of this, stated with the estimate: 35%); at least 6.6-fold (0.82 log units) between middle value and limit.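

Going by these compounds alone, compound 4 gives only a limit, > 10000 nM, and compound 2 is also a limit, so no step between compound 2 and compound 4 can be read. The compounds shown leave open which structural change, if any, would yield a measurable inhibition value.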